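Cyclohexyl for 3-methoxyphenyl on the ring amide nitrogen

The source may hold more compounds than are shown below. What is called first, only, known or untested is meant among the compounds shown, and "the series" means these compounds.

Measured compounds:
- compound 1 `COc1cccc(N2C(=O)COc3ccc(-c4cnc(OC)c(NS(=O)(=O)c5ccc(F)cc5)c4)cc32)c1`: > 40000 nM, a limit of the assay, not a number
- compound 2 `COc1ncc(-c2ccc3c(c2)N(C2CCCCC2)C(=O)CO3)cc1NS(=O)(=O)c1ccc(F)cc1`: > 40000 nM, likewise a limit
- compound 3 `COc1cccc(N2C(=O)COc3ccc(-c4cnc5ccccc5c4)cc32)c1`: 2080 nM

Among the measured compounds shown here, in a functional assay on HepG2 cells (Homo sapiens) for antiproliferative activity, read by MTT assay, with a stated time of 72 h (on this read-out lower numbers stand for stronger inhibition and higher numbers for weaker inhibition), compound 3 gives the only number in the set. Compound 1 and compound 2 both sit at the limit of > 40000 nM in this assay, at which 2 of the 3 values shown sit. The change from compound 1 to compound 2 is cyclohexyl in place of 3-methoxyphenyl on an amide-type nitrogen in a ring; its step, a step that the two limits leave unreadable from compound 1 to compound 2, cannot be read from two limits. The difference between the core of compound 1 and the core of compound 3 is not broken down here.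

Compound 4 `O=C1COc2ccc(-c3cnc4ccccc4c3)cc2N1C1CCCCC1` is not yet measured. It differs from compound 3 by cyclohexyl in place of 3-methoxyphenyl on an amide-type nitrogen in a ring, the same kind of change as from compound 1 to compound 2. For the measured compounds named here, no measured step gives its size, so for compound 4 a step of a 1.7-fold higher number from compound 3 to compound 4 (0.23 log units; within the scatter) is expected, with wide bounds. Compound 4 is estimated at 3500 nM in this assay, from 800 nM to 20000 nM.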

Compound 4, half-maximal inhibitory concentration: > 40000 nM
Compound 4 was reported as a limit; the forecaster's own chance of this, stated with the estimate: 20%; middle value at least 11-fold (1.05 log units) away from the limit.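

On the core of compound 3, cyclohexyl in place of 3-methoxyphenyl on the amide-type nitrogen in a ring gives, in this assay, an at least 19-fold higher number from compound 3 to compound 4 (1.28 log units; beyond the scatter). Compound 4 stands at a limit of the assay, not a number, so this step marks only the smallest size the change can have on this core. The same change on the core of compound 1 cannot be read, which leaves one readable case and shows neither that the step carries from one core to another nor that it does not: the limit of > 40000 nM in this assay, at which 3 of the 4 values shown sit.

Open, going by these compounds, is whether an unsubstituted phenyl or a benzyl on that nitrogen would stay near compound 3 at 2080 nM. Also open, on these data alone, is whether the step follows from losing the methoxy group or from losing the aromatic ring.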